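A Methyl on the Ring Carbon of Compound 2

A few compounds are considered here, and "the series" means these few. Any claim that something is new, unique, unknown or untested is made for them only; others in the source may bear on it.

Compound 1 `O=C(NCc1cc(C(F)(F)F)cc(C(F)(F)F)c1)c1cnc2ccccc2c1-c1ccccc1` in an in vitro assay on UC11MG cells for binding affinity to Substance-P receptor (Homo sapiens), read by radioligand binding (on this read-out higher numbers stand for weaker inhibition and lower numbers for stronger inhibition), gives only a limit, > 1000 nM.
Compound 2 `CN(Cc1cc(C(F)(F)F)cc(C(F)(F)F)c1)C(=O)c1cnc2ccccc2c1-c1ccccc1` in this assay gives 0.03 nM.

The value of compound 1 is a limit, (the limit of > 1000 nM in this assay, at which 1 of the 2 values shown sits). Compound 2 therefore holds the only number shown. Compound 3 `Cc1nc2ccccc2c(-c2ccccc2)c1C(=O)N(C)Cc1cc(C(F)(F)F)cc(C(F)(F)F)c1` differs from compound 2 by methyl in place of hydrogen on an aromatic carbon. For the measured compounds named here, the single measured step, an at least 33000-fold lower number from compound 1 to compound 2 (4.52 log units; beyond the scatter), concerns a methyl on the amide nitrogen, not on an aromatic carbon, so it does not bear directly on this change. Going by the values given here, with no measured step on a ring methyl, the expected step in this assay is small, a 1.7-fold higher number from compound 2 to compound 3 (0.22 log units; within the scatter). Compound 3 is estimated at 0.05 nM, between 0.01 nM and 0.3 nM.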

Compound 3, half-maximal inhibitory concentration: 3.1 nM
For compound 3 the middle estimate is 62-fold (1.79 log units) below the measured one; measured number above the stated range.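

A methyl on the aromatic carbon next to the ring nitrogen brings a 100-fold higher number from compound 2 to compound 3 (2.01 log units; beyond the scatter), so this position responds strongly to the addition of a single carbon atom. The change runs in the opposite direction to the methyl on the amide nitrogen, which lowered the number. Nothing in the data shown explains this loss of binding strength.

From the compounds shown here alone, it remains open whether a longer chain such as ethyl, a fluorine atom or an amine at this carbon would weaken binding as much, or less.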